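A few compounds are considered here, and "the series" means these few. Any claim that something is new, unique, unknown or untested is made for them only; others in the source may bear on it.

In a functional assay on the whole organism for inhibition, with Rattus norvegicus as the target (a higher number here means that more compound is needed for the effect, a lower number that less compound is needed), compound 1 `CC(C)c1ccc(OC(Cc2ccccc2)C(=O)O)cc1` gives 50 mg/kg. Compound 2 `CC(C)c1ccc(OC(C)(Cc2ccccc2)C(=O)O)cc1` stands only at a limit of the assay, > 10 mg/kg. Compound 3 `CC(C)c1ccc(OC(C)(Cc2ccc(C(F)(F)F)cc2)C(=O)O)cc1` also has only a limit, < 5 mg/kg.

Compound 4 `Cc1cccc(CC(C)(Oc2ccc(C(C)C)cc2)C(=O)O)c1` differs from compound 2 by methyl in place of hydrogen on an aromatic carbon, meta to a large group. Two measured steps are available. The chain change gives a step that the limit leaves unreadable from compound 1 to compound 2, which offers no size. The closest guide is trifluoromethyl on an aromatic carbon, with an at least 2.0-fold lower number from compound 2 to compound 3 (0.30 log units; that floor lies within the scatter), a different group and a floor only. A small move to a lower number, hardly beyond the scatter, is therefore expected, and the expected step is a step that the limit leaves unreadable from compound 2 to compound 4. For compound 4 the estimated value is 15 mg/kg, with an expected range of 5 mg/kg to 45 mg/kg.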

Compound 4, dose for half-maximal effect: < 1 mg/kg
Compound 4: a limit, no number (the forecaster's own chance of this, stated with the estimate: 40%); at least 15-fold (1.17 log units) between middle value and limit.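

In this assay, methyl in place of hydrogen on an aromatic carbon, meta to a large group, gives an at least 10-fold lower number from compound 2 to compound 4 (1.00 log units; beyond the scatter). Among the compounds shown here, this is the first step printed as beyond the scatter, and it shows that this ring position responds strongly to a single added methyl, whereas the trifluoromethyl change gives only an at least 2.0-fold lower number from compound 2 to compound 3 (0.30 log units; that floor lies within the scatter). Both values behind the methyl step are limits, so its size is a floor and not a measured difference.

From the compounds shown here alone, compound 4 gives < 1 mg/kg, a limit, so its actual dose remains open. Going by these compounds, whether methoxy or chlorine in place of this methyl would keep the lower number also remains open.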